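Estimating compound 4 from compound 1 and its neighbours

The compounds below may be only part of what the source reports. "The series", "measured", "known", "first", "only" and "open" are said of these compounds alone.

Measured in a functional assay on L1210 cells (Mus musculus) for inhibition, read by MTT assay, with a stated time of 72 h; on this read-out higher numbers stand for weaker inhibition and lower numbers for stronger inhibition:
Compound 1 `COc1cc(NC(C)CCCNC(=O)Nc2ccc(F)cc2)c2ncccc2c1`: 18000 nM
Compound 2 `COc1cc(NC(C)CCCNC(=O)NNC(=O)Nc2cccc(Cl)c2)c2ncccc2c1`: 27000 nM
Compound 3 `COc1cc(NC(C)CCCNC(=O)Nc2cccc(O)c2)c2ncccc2c1`: 25000 nM

Among the measured compounds shown here, compound 1 has the lowest of the three numbers, but its steps to the others, a 1.4-fold higher number from compound 1 to compound 3 (0.14 log units; within the scatter) and a 1.5-fold higher number from compound 1 to compound 2 (0.18 log units; within the scatter), are both within the scatter, so no compound can be called stronger or weaker here. Compound 4 `COc1cc(NC(C)CCCNC(=O)NNC(=O)Nc2ccc(Cl)cc2)c2ncccc2c1` differs from compound 1 in one place: ((4-chlorophenyl)carbamoyl)amino in place of 4-fluorophenyl on an amide-type nitrogen. The closest comparison is the step to compound 2, where a ((3-chlorophenyl)carbamoyl)amino group entered in the same place and produced only a 1.5-fold higher number from compound 1 to compound 2 (0.18 log units; within the scatter), within the scatter. The same kind of change, with chlorine at the 4-position of the ring, is therefore expected to give a 1.3-fold higher number from compound 1 to compound 4 (0.12 log units; within the scatter), no shift beyond the scatter. Compound 4 is estimated at 24000 nM, in the range 12000 nM to 48000 nM.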

Compound 4, half-maximal inhibitory concentration: 58000 nM
Beside the measured number, compound 4's estimate is 2.4-fold (0.38 log units) below it; the measured number lies above the stated range.
By their numbers in this assay, from the lowest: compounds 1, 3 and 2 (each within the scatter of the next); then compound 4.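

In this assay, among the compounds shown here, putting 4-chlorophenyl in place of 3-chlorophenyl gives a 2.1-fold higher number from compound 2 to compound 4 (0.33 log units; beyond the scatter), so this place responds to where the chlorine sits on the ring, which the earlier compounds could not show. The ((4-chlorophenyl)carbamoyl)amino group also separates from the earlier groups, with a 3.2-fold higher number from compound 1 to compound 4 (0.51 log units; beyond the scatter) and a 2.3-fold higher number from compound 3 to compound 4 (0.37 log units; beyond the scatter), each modest and toward weaker inhibition. No measurement here accounts for this shift.

Still open, on these data alone, is whether the chlorine's ring position matters without the added carbamoyl amino link. As far as these compounds go, a bromine, an amine or a carboxylic acid on that ring also remains untested in these compounds.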